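A few compounds are considered here, and "the series" means these few. Any claim that something is new, unique, unknown or untested is made for them only; others in the source may bear on it.

Compound 1 `CC/C(=C(/c1ccc(/C=C/C(=O)O)cc1)c1ccc2[nH]ncc2c1Cl)c1ccccc1`: 1.6 nM
Compound 2 `CS(=O)(=O)c1ccc(/C(=C(\c2ccc(/C=C/C(=O)O)cc2)c2ccc3[nH]nc(F)c3c2)C2CCC2)c(Cl)c1`: 2.3 nM
Compound 3 `O=C(O)/C=C/c1ccc(/C(=C(\c2ccc(C(F)(F)F)cc2Cl)C2CCC2)c2ccc3[nH]nc(F)c3c2)cc1`: 8.2 nM

In a functional assay on MCF7 cells (Homo sapiens) for cytotoxicity, read by CellTiter-Glo, with a stated time of 5 days (a higher number here means a weaker inhibitor, a lower number a stronger inhibitor), compound 3 gives the highest of the three numbers; compound 2 sits nearest to it and compound 1 furthest from it. The step from compound 3 to compound 4 `Cc1cccnc1/C(=C(\c1ccc(/C=C/C(=O)O)cc1)c1ccc2[nH]nc(F)c2c1)C1CCC1` is 3-methylpyridin-2-yl in place of 2-chloro-4-(trifluoromethyl)phenyl on a double-bonded chain carbon bound to a double-bonded chain carbon and a saturated ring carbon. Within the data shown here, no measured step exchanges the whole aryl group at that carbon; the one measured step, a 3.6-fold higher number from compound 2 to compound 3 (0.55 log units; beyond the scatter), only swaps a substituent on that ring, and it is modest. Because compound 2 gives 2.3 nM and compound 1 gives 1.6 nM with other groups at this carbon, a modest move back toward lower numbers in this assay is expected for compound 4, though with wide uncertainty. Compound 4 is therefore estimated at 4 nM, within 1.5 nM to 12 nM. That estimate means an expected step of a 2.1-fold lower number from compound 3 to compound 4 (0.31 log units; beyond the scatter).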

Compound 4, half-maximal inhibitory concentration: 4.2 nM
Estimate against measurement, compound 4: 1.1-fold (0.02 log units) below; low and high end bracket the measured number.
By their numbers in this assay, from the lowest: compounds 1, 2, 4 and 3 (each within the scatter of the next, the first and the last beyond it).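

In this assay, among these compounds, the earlier compounds changed only a substituent on the ring at this carbon, whereas here the whole aryl group is exchanged: 3-methylpyridin-2-yl replaces 2-chloro-4-(trifluoromethyl)phenyl, giving a 2.0-fold lower number from compound 3 to compound 4 (0.29 log units; within the scatter). Against 2-chloro-4-(methylsulfonyl)phenyl the same group gives a 1.8-fold higher number from compound 2 to compound 4 (0.26 log units; within the scatter), so this position accepts an aromatic ring with a hetero atom and no chlorine without a change beyond the scatter. No available evidence explains this result. The compounds shown do not separate the contributions of the methyl group and the ring nitrogen. From the compounds shown here alone, how a morpholine ring or an aminomethyl group would fare on this carbon also remains open.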